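Notes on compound 3 within the shared series

This account rests on a few compounds, and the source may have more. Where it says the series, first, only, none or still open, it means among the compounds named here.

Measured so far:
compound 1 `Nc1scc(CN2CCN(c3cccc(C(F)(F)F)c3)CC2)c1C(=O)c1ccc(Cl)cc1` — -30%
compound 2 `Nc1scc(CN2CCN(c3c(F)cccc3F)CC2)c1C(=O)c1ccc(Cl)cc1` — -23%

Both measured compounds share one core and differ only in the group on the amine nitrogen in a ring. In a functional assay on CHO cells with adenosine receptor A1 (Homo sapiens) as the target, read by cAMP accumulation and immunoassay, with a stated time of 6 min, tested at 0.1 uM (a lower number here means a stronger effect, a higher number a weaker effect of the compound at the concentration tested), compound 1 gives -30%, and compound 2 gives -23%. The step of a number 7 percentage points higher from compound 1 to compound 2 (within the scatter) lies within the scatter, so compound 2 stands at the higher of the two numbers without being separated from compound 1 by anything the assay can resolve.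

Compound 3 `Nc1scc(CN2CCN(c3cc(Cl)ccc3Cl)CC2)c1C(=O)c1ccc(Cl)cc1` has not yet been measured. It differs from compound 2 by 2,5-dichlorophenyl in place of 2,6-difluorophenyl on an amine nitrogen in a ring. For the measured compounds named here, the one measured step, a number 7 percentage points higher from compound 1 to compound 2 (within the scatter), also exchanges one aromatic group for another on the same ring nitrogen and stays within the scatter; no measured step involves a dichlorophenyl group on that nitrogen. The expectation is therefore a step of a number 2 percentage points lower from compound 2 to compound 3 (within the scatter) no larger than the scatter, in no set direction. Compound 3 is estimated at -25% in this assay, with a range from -45% to -5%.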

Compound 3, a percentage reported as activity, at one concentration (the size of the read-out at that concentration, not a potency): -6.2%
Compound 3: the middle estimate sits 18.8 percentage points below what was measured, and the stated range covers the measured number.
By their numbers in this assay, from the lowest: compounds 1 and 2 (each within the scatter of the next); then compound 3.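

The group on the amine nitrogen in a ring is not indifferent in this assay: with a number 16.8 percentage points higher from compound 2 to compound 3 (beyond the scatter) and a number 23.8 percentage points higher from compound 1 to compound 3 (beyond the scatter), exchanging one aromatic group for another at this place now moves the read-out beyond the scatter, which a number 7 percentage points higher from compound 1 to compound 2 (within the scatter) did not do. This separation appears although 2,5-dichlorophenyl and 2,6-difluorophenyl have the same count of heavy atoms, each holds one six-membered aromatic ring of carbon only, and neither carries a net charge, leaving compound 3 with the weakest effect of the three at the tested concentration. No measurement among the data offers an explanation for the shift.

The exchange from compound 2 to compound 3 alters both the halogen and the substitution pattern, so a 2,5-difluorophenyl or 2,6-dichlorophenyl group on the same nitrogen would be needed to tell these two changes apart. Open as well is how a non-aromatic group such as cyclohexyl would read at this place, and, with a read-out at a single concentration, whether these differences carry over to potency.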